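Compound 4: ethoxy in place of chloro

The source may hold more compounds than are shown below. What is called first, only, known or untested is meant among the compounds shown, and "the series" means these compounds.

Going by the values given here, in a physicochemical assay for solubility, read by HPLC, with a stated time of 4 h, at pH 7 (on this read-out lower numbers stand for lower solubility and higher numbers for higher solubility), compound 3 `C[C@]1(COc2ccc(NC(=O)Nc3ccc(Cl)cc3)cc2)Cn2cc([N+](=O)[O-])nc2O1` gives 6.66 ug/mL, the only true number so far. Compound 1 `CC(C)(C)c1ccc(NC(=O)Nc2ccc(OC[C@@]3(C)Cn4cc([N+](=O)[O-])nc4O3)cc2)cc1` gives < 1 ug/mL, which is a limit. Compound 2 `Cc1ccc(NC(=O)Nc2ccc(OC[C@@]3(C)Cn4cc([N+](=O)[O-])nc4O3)cc2)cc1` gives < 1 ug/mL, also a limit.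

Compound 4 `CCOc1ccc(NC(=O)Nc2ccc(OC[C@@]3(C)Cn4cc([N+](=O)[O-])nc4O3)cc2)cc1` carries ethoxy in place of chloro on an aromatic carbon, para to a large group. Among the compounds with values here, two measured steps bear on it: chloro in place of tert-butyl gave an at least 6.6-fold higher number from compound 1 to compound 3 (0.82 log units; beyond the scatter), and chloro in place of methyl gave an at least 6.6-fold higher number from compound 2 to compound 3 (0.82 log units; beyond the scatter). Within the data shown here, neither step involves ethoxy, yet compound 3 at 6.66 ug/mL is the only member with a true number, so a lower number is expected in this assay. The expected change is a 3.3-fold lower number from compound 3 to compound 4 (0.52 log units; beyond the scatter). Compound 4 is estimated at 2 ug/mL, with an expected range of 0.7 ug/mL to 6 ug/mL.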

Compound 4, solubility: 6.66 ug/mL
For compound 4 the middle estimate is 3.3-fold (0.52 log units) below the measured one; measured number above the stated range.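

In this assay, ethoxy in place of chloro on this aromatic carbon gives no change at the digits printed from compound 3 to compound 4 (within the scatter), so a second group at this position reads clear of the limit. The same group gives an at least 6.6-fold higher number from compound 2 to compound 4 (0.82 log units; beyond the scatter) and an at least 6.6-fold higher number from compound 1 to compound 4 (0.82 log units; beyond the scatter). The true size of both steps stays unknown, since compound 1 and compound 2 each sit at a limit: the limit of < 1 ug/mL in this assay, at which 2 of the 4 values shown sit.

Going by these compounds, how an amine, a carboxylic acid or a longer alkoxy chain at this position would read in this assay remains open. Any change to the shared core also remains open.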